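A few compounds are considered here, and "the series" means these few. Any claim that something is new, unique, unknown or untested is made for them only; others in the source may bear on it.

Compound 1 `CC(Sc1nnc(-c2ccncc2)s1)C(=O)Nc1ccccc1Cl` and compound 2 `CC(Sc1nnc(-c2ccncc2)s1)C(=O)Nc1c(Cl)cccc1Cl` share a core and differ only in hydrogen in place of chloro on an aromatic carbon. In an ADME assay on HepG2 cells (Homo sapiens) for cytotoxicity, with a stated time of 3 days (on this read-out lower numbers stand for higher toxicity in this test and higher numbers for lower toxicity in this test), compound 1 gives only the assay limit > 50000 nM. Compound 2 likewise gives only the limit > 50000 nM. The step that the two limits leave unreadable from compound 2 to compound 1 therefore cannot be read, since both values sit at the limit of > 50000 nM in this assay, at which 2 of the 3 values shown sit. Compound 3 `CC(CSc1nnc(-c2ccncc2)s1)C(=O)NCc1ccc(Cl)cc1` carries a different core, and the difference between the two cores is not broken down here; for compound 3 the entry in this assay reads "not determined" (no result reported), so no result was reported. Compound 4 `CC(CSc1nnc(-c2ccncc2)s1)C(=O)NCc1ccccc1` differs from compound 3 in hydrogen in place of chloro on an aromatic carbon, the same kind of change as between compound 2 and compound 1, though here the place lies para to a large group rather than ortho to a large group and meta to a chloro group. With compound 1 and compound 2 both at the limit (the limit of > 50000 nM in this assay, at which 2 of the 3 values shown sit), a value at the limit is expected for compound 4 as well, estimated at 60000 nM, within 25000 nM to 200000 nM.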

Compound 4, half-maximal cytotoxic concentration: > 50000 nM
Compound 4 was reported as a limit; the forecaster's own chance of this, stated with the estimate: 80%; the middle value does not contradict the limit.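

Compound 4 gives only a limit, > 50000 nM. Going by these compounds alone, compound 3 has no reported result, so no step between compound 3 and compound 4 can be read. The compounds shown leave open whether replacing chloro with hydrogen changes cytotoxicity at all.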